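Swapping an acetyl for a cyano on the sulfonyl-bearing chain carbon

The source may report more compounds than this note shows. Statements on the series, on what has been measured and on what is new or still open speak of the compounds shown alone.

Two compounds share an indole-like core carrying a phenyl and a two-carbon chain that ends in electron-poor groups. Compound 1 `COc1ccc2[nH]c(-c3ccccc3)c(C=C(C#N)C#N)c2c1` carries two cyano groups on that chain and a methoxy on the core; in a functional assay on SK-MEL-2 cells (Homo sapiens) for inhibition, read by sulforhodamine B assay, with a stated time of 48 h (a higher number here means a weaker inhibitor of growth, a lower number a stronger inhibitor of growth), compound 1 gives 5900 nM. Compound 2 `CC(=O)/C(=C\c1c(-c2ccccc2)[nH]c2ccccc12)S(=O)(=O)c1ccccc1` carries an acetyl and a phenylsulfonyl on the chain; in this assay compound 2 gives 1400 nM. Compound 2 therefore has the lower of the two numbers, and the gap to compound 1 lies beyond the usual scatter, so compound 2 is the stronger growth inhibitor of the pair.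

Compound 3 `N#C/C(=C\c1c(-c2ccccc2)[nH]c2ccccc12)S(=O)(=O)c1ccccc1` has not yet been measured. It differs from compound 2 in one place: cyano in place of acetyl on a double-bonded chain carbon bound to a double-bonded chain carbon and a sulfonyl sulfur. Among the measured compounds shown here, no measured pair shows exactly this change, so its effect is uncertain. For the measured compounds named here, a modest weakening is expected, since compound 1, the only other compound with a cyano on the chain, gives 5900 nM. The step from compound 2 to compound 3 is estimated at a 1.6-fold higher number from compound 2 to compound 3 (0.20 log units; within the scatter), roughly at the edge of the scatter. In this assay compound 3 is estimated at 2200 nM, within a range from 700 nM to 7000 nM.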

Compound 3, concentration for 50% growth inhibition: 12700 nM
For compound 3 the middle estimate is 5.8-fold (0.76 log units) below the measured one; measured number outside the range, above it.
By their numbers in this assay, from the lowest: compound 2; then compound 1; then compound 3.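

In this assay, among the compounds shown here, this is the first pair that differs in one place only, so the change on a double-bonded chain carbon bound to a double-bonded chain carbon and a sulfonyl sulfur can be read on its own: cyano in place of acetyl gives a 9.1-fold higher number from compound 2 to compound 3 (0.96 log units; beyond the scatter). This step lies beyond the usual scatter, so the group at this position matters for growth inhibition, and here the acetyl goes with the stronger inhibitor. The swap replaces 3 heavy atoms with 2 and leaves the hydrogen-bond donor and acceptor counts unchanged, but no measurement is available to explain the difference in growth inhibition.

On these data alone, it remains open whether the loss reflects the arrival of the cyano or the departure of the acetyl, and whether a methyl ester or a longer ketone such as propanoyl at this position would sit closer to compound 2 or to compound 3. As far as these compounds go, it is also open whether the same swap would have a similar effect on a core carrying the methoxy of compound 1.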